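Swapping a methyl for a methoxy on the half-life read-out

The source may hold more compounds than are shown below. What is called first, only, known or untested is meant among the compounds shown, and "the series" means these compounds.

Measured so far in an ADME assay; on this read-out lower numbers stand for a shorter-lived compound and higher numbers for a longer-lived compound (values below):
- compound 1 (`COc1ccc(C[S+]([O-])c2ncccc2C(=O)Nc2ccncc2)c(OC)c1C`) gives 0.12 h as a number
- compound 2 (`CCOc1ccc(C[S+]([O-])c2ncccc2C(=O)Nc2ccncc2)c(OCC)c1`) gives < 0.02 h as a limit of the assay
- compound 3 (`COc1cc(OC)c(OC)cc1C[S+]([O-])c1ncccc1C(=O)Nc1ccncc1`) gives < 0.02 h as a limit of the assay

Within the data shown here, compound 1 is the only one with a real number, while the other two sit at the limit of < 0.02 h in this assay, at which 2 of the 3 values shown sit, and give none. Compound 4 (`COc1ccc(C[S+]([O-])c2ncccc2C(=O)Nc2ccncc2)c(OC)c1OC`) differs from compound 1 by one group (methoxy in place of methyl on an aromatic carbon): methoxy in place of methyl on an aromatic carbon, ortho to two methoxy groups. Among the measured compounds shown here, no measured pair shows this change alone. Compound 3 likewise carries methoxy groups and no methyl, and its < 0.02 h is a limit. A modest shortening, slightly beyond the scatter, is therefore expected in this assay as the estimated 2.4-fold lower number from compound 1 to compound 4 (0.38 log units; beyond the scatter) for this change. Compound 4 is expected at 0.05 h (estimated range 0.02 h to 0.15 h).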

Compound 4, half-life: 0.45 h
The estimate for compound 4 lay 9.0-fold (0.95 log units) below the measured number, and the stated range ends below it.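

In this assay, methoxy in place of methyl on this aromatic carbon, ortho to two methoxy groups, gives a 3.8-fold higher number from compound 1 to compound 4 (0.57 log units; beyond the scatter), so the swap lengthens the half-life here. Among these compounds, this is the first single change at this place that can be read as a step. Compound 2 and compound 3 offer no second reading of it, because each stands at a limit of the assay: the limit of < 0.02 h in this assay, at which 2 of the 4 values shown sit.

From the compounds shown here alone, whether an ethoxy group or an amine at this same place would lengthen the half-life further stays open. So does whether the swap acts the same way at other places on the ring.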